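Swapping tert-butyl for hydrogen on compound 2

This account rests on a few compounds, and the source may have more. Where it says the series, first, only, none or still open, it means among the compounds named here.

- compound 1 `Cn1nc(C(F)(F)F)cc1C(=O)Nc1ccc(S(=O)(=O)OC2CCCCC2)cc1`: > 300000 nM
- compound 2 `Cn1nc(C(F)(F)F)cc1C(=O)Nc1ccc(S(=O)(=O)N2CCCCC2C(=O)OC(C)(C)C)cc1`: 38000 nM

In an ADME assay on Vero cells (Chlorocebus sabaeus) for cytotoxicity, read by MTT assay (on this read-out higher numbers stand for lower toxicity in this test and lower numbers for higher toxicity in this test), compound 1 reports only a limit, > 300000 nM. For the measured compounds named here, compound 2 gives 38000 nM, the only exact number so far. Compound 3 `Cn1nc(C(F)(F)F)cc1C(=O)Nc1ccc(S(=O)(=O)N2CCCCC2C(=O)O)cc1` differs from compound 2 by hydrogen in place of tert-butyl on an oxygen next to a carbonyl group, so tert-butoxycarbonyl becomes carboxy. Going by the values given here, no measured pair shows this change, so the size of the step is uncertain. A moderate rise in this assay, beyond the usual scatter, is expected, with the estimated step of a 3.2-fold higher number from compound 2 to compound 3 (0.50 log units; beyond the scatter). Compound 3 is estimated at 120000 nM, within a range of 45000 nM to 300000 nM.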

Compound 3, half-maximal cytotoxic concentration: > 300000 nM
Compound 3: no number, only a limit; the forecaster's own chance of this, stated with the estimate: 40%; at least 2.5-fold (0.39 log units) between middle value and limit.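

In this assay, hydrogen in place of tert-butyl on this oxygen, turning tert-butoxycarbonyl into carboxy, gives an at least 7.8-fold higher number from compound 2 to compound 3 (0.89 log units; beyond the scatter). For the compounds shown here, this is the only measured pair for this change, and it shows that the change moves the read-out well beyond the usual scatter towards lower toxicity in this test. The value of compound 3 is a limit, so the true size of the step stays unknown: the limit of > 300000 nM in this assay, at which 2 of the 3 values shown sit.

The step between compound 1 and compound 3 cannot be read, as both values are limits. Still open, on these data alone, is whether a methyl ester or a primary amide at this place would stay at the limit or come closer to compound 2.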